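The source may report more compounds than this note shows. Statements on the series, on what has been measured and on what is new or still open speak of the compounds shown alone.

Working notes on the series. The compounds share one core; the group on an aromatic nitrogen of a five-membered aromatic ring with 3 nitrogen is varied. Compound 1 `COc1ccc(/C=C\C(=O)O)c(OCc2cn(-c3ccc(NC(C)=O)cc3)nn2)c1CC=C(C)C` and compound 2 `COc1ccc(/C=C\C(=O)O)c(OCc2cn(-c3ccccc3F)nn2)c1CC=C(C)C` carry numbers; compound 3 `COc1ccc(-n2cc(COc3c(/C=C\C(=O)O)ccc(OC)c3CC=C(C)C)nn2)cc1` does not. In a functional assay on T47D cells (Homo sapiens) for cytotoxicity, read by MTT assay, with a stated time of 24 h (on this read-out lower numbers stand for stronger inhibition and higher numbers for weaker inhibition), compound 1 gives 17400 nM. In this assay compound 2 gives 11000 nM. For compound 3 this assay records "not determined" (no result reported). Among the measured compounds shown here, the single one-place step so far, a 1.6-fold lower number from compound 1 to compound 2 (0.20 log units; within the scatter), falls within the scatter. Of the two numbers shown, that of compound 2 is the lower one, but the gap to compound 1 is within the scatter and so marks no real difference.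

Compound 4 `COc1ccc(/C=C\C(=O)O)c(OCc2cn(-c3cccc([N+](=O)[O-])c3)nn2)c1CC=C(C)C` is the next entry. Its change from compound 2: 3-nitrophenyl in place of 2-fluorophenyl on an aromatic nitrogen. For the measured compounds named here, the only measured step that bears on it is the exchange at the same aromatic nitrogen, a 1.6-fold lower number from compound 1 to compound 2 (0.20 log units; within the scatter), which stayed within the scatter; no other measured pair touches this position, and compound 3 contributes no number. A step beyond the scatter is therefore not expected in this assay. For compound 4 the expected value in this assay is 12000 nM, with a range from 5000 nM to 30000 nM. This estimate means an expected step of a 1.1-fold higher number from compound 2 to compound 4 (0.04 log units; within the scatter), inside the scatter.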

Compound 4, half-maximal inhibitory concentration: 15400 nM
Estimate against measurement, compound 4: 1.3-fold (0.11 log units) below; the measured number falls inside the stated range.
By their numbers in this assay, from the lowest: compounds 2, 4 and 1 (each within the scatter of the next).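

In this assay, 3-nitrophenyl in place of 2-fluorophenyl on the aromatic nitrogen gives a step within the scatter (a 1.4-fold higher number from compound 2 to compound 4 (0.15 log units; within the scatter)), and so does 3-nitrophenyl in place of 4-acetamidophenyl (a 1.1-fold lower number from compound 1 to compound 4 (0.05 log units; within the scatter)). The position now has three measured phenyl groups, with the substituent named at 2, 3 or 4, and all three numbers lie within the scatter of one another, so none of these exchanges separates compounds 1, 2 and 4. This holds even though 3-nitrophenyl counts 2 hydrogen-bond acceptors and a double bond outside aromatic rings, where 2-fluorophenyl counts neither, and no measured property of these groups is at hand to interpret the result.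

The compounds shown leave open whether any group on this nitrogen can move the number beyond the scatter, for instance a phenyl bearing an amine or a carboxylic acid, or a longer alkyl chain in place of the phenyl. They also leave open whether the same flat picture holds when the shared core itself is changed rather than this position.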